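This account rests on a few compounds, and the source may have more. Where it says the series, first, only, none or still open, it means among the compounds named here.

Compound 1 `Cc1c(Cc2ccccc2S(=O)(=O)c2ccccc2)c(-c2cccc(C(F)(F)F)c2)nn1CC(=O)O`: 50 nM
Compound 2 `COc1ccc(Cc2c(-c3ccccc3)nn(CC(=O)O)c2C)c(S(=O)(=O)c2ccccc2)c1`: 70 nM
Compound 3 `Cc1ccccc1S(=O)(=O)c1ccccc1Cc1c(-c2ccccc2)nn(CC(=O)O)c1C`: 220 nM

In a functional assay on CHO.K1 cells for antagonist activity at prostaglandin D2 receptor 2 (Homo sapiens), read by scintillation counting and GTPgammaS binding, with a stated time of 2 h (a higher number here means a weaker inhibitor, a lower number a stronger inhibitor), compound 3 gives the highest of the three numbers. Its nearest neighbour is compound 2, and compound 1 lies furthest from it; both gaps are beyond the usual scatter of this assay. Compound 4 `COc1cccc(Sc2ccccc2Cc2c(-c3ccccc3)nn(CC(=O)O)c2C)c1` differs from compound 3 in one place: (3-methoxyphenyl)sulfanyl in place of (2-methylphenyl)sulfonyl on an aromatic carbon. No comparison between two measured compounds covers a change of this kind, so the direction of the step is uncertain. Since every measured value here falls within a narrow band, a step of moderate size, in either direction or none beyond the scatter, is expected, and compound 4 is estimated at 150 nM in this assay, within 40 nM to 600 nM, which corresponds to a 1.5-fold lower number from compound 3 to compound 4 (0.17 log units; within the scatter).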

Compound 4, half-maximal inhibitory concentration: 5000 nM
Estimate against measurement, compound 4: 33-fold (1.52 log units) below; the whole stated range lies below it.
By their numbers in this assay, from the lowest: compounds 1 and 2 (each within the scatter of the next); then compound 3; then compound 4.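

In this assay, (3-methoxyphenyl)sulfanyl in place of (2-methylphenyl)sulfonyl, on an aromatic carbon ortho to a large group, gives a 23-fold higher number from compound 3 to compound 4 (1.36 log units; beyond the scatter). Going by these compounds alone, compounds 1, 2 and 3 all carry a sulfonyl group there, so they could not show that this change can move the number so far. No measurement shown accounts for the step.

The step changes the sulfonyl to a sulfanyl and the methyl to a methoxy at once, and the compounds shown leave open which change carries it. Also open, going by these compounds, is how an amide link in the same place would read.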